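Chloro for bromo on the aryl ring: compound 4

The source may report more compounds than this note shows. Statements on the series, on what has been measured and on what is new or still open speak of the compounds shown alone.

Measured compounds in a functional assay on NCI-H292 cells (Homo sapiens) for cytotoxicity, read by MTT assay, with a stated time of 72 h, tested at 5 ug/mL; a lower number here means less inhibition of growth, a higher number more inhibition of growth at the concentration tested:
- compound 1, `O=C1NC(=S)/C(=C/c2cc(Cl)cc(Cl)c2Cl)S1`, gives 39.7%
- compound 2, `O=C1NC(=S)/C(=C/c2ccccc2Br)S1`, gives 22.9%
- compound 3, `O=C1NC(=S)/C(=C/c2cccc(Cl)c2)S1`, gives 21.6%

Compound 2 stands second highest of the three numbers in this assay. Its nearest neighbour is compound 3, whose value is only slightly lower, a gap that lies within the usual scatter of this read-out; the two cannot be told apart. The furthest is compound 1, whose value is higher by a margin beyond the scatter.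

Compound 4, `O=C1NC(=S)/C(=C/c2ccccc2Cl)S1`, has not yet been measured in this assay. It differs from compound 2 in one place: chloro in place of bromo on an aromatic carbon. The shared core and the alkene linker are unchanged.

Within the data shown here, no pair of measured compounds differs in a single place, so no measured step informs this change directly. Given that the substituent is swapped for another single halogen at the same position, and that compound 2 and compound 3 already sit within the scatter of each other despite a different halogen pattern, the step of a number 0.9 percentage points lower from compound 2 to compound 4 (within the scatter) is expected to be small, probably not beyond the scatter, with no clear direction.

Compound 4 is therefore estimated to give 22% in this assay, with a plausible range from 10% to 35%.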

Compound 4, percent growth inhibition at one concentration: 34.2%
Compound 4: middle estimate off by 12.2 percentage points, on the low side; low and high end bracket the measured number.
By their numbers in this assay, from the lowest: compounds 3 and 2 (each within the scatter of the next); then compounds 4 and 1 (each within the scatter of the next).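

Under this assay the change of bromo to chloro on the aromatic carbon ortho to a group of 8 heavy atoms gives a number 11.3 percentage points higher from compound 2 to compound 4 (beyond the scatter) and is the first step in the series that can be read at a single place. This position is therefore sensitive to which halogen it carries: exchanging one single halogen for another, with the shared core and the alkene linker untouched, is enough to move the read-out past the usual scatter. Nothing measured on these compounds bears on why the number moves.

On these data alone, what remains open is how far this reaches, since one step at one position gives neither a trend across the halogens nor a direction for other kinds of substituent, so fluoro, iodo, methoxy or an amine at this carbon could each fall on either side of compound 4. As far as these compounds go, it is also open whether the same exchange of bromo for chloro would give a step of similar size at another carbon of the aromatic ring, or on a ring carrying further halogens, as in compound 1.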